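A few compounds are considered here, and "the series" means these few. Any claim that something is new, unique, unknown or untested is made for them only; others in the source may bear on it.

Measured so far:
compound 1 `CCCc1nc(-c2ccccc2)c(CNCCN2CCN(c3ccccc3OC)CC2)o1`: 39.7%
compound 2 `CCCc1nc(-c2ccccc2)c(CNCCCN2CCN(c3cccc(Cl)c3)CC2)o1`: 65.9%
compound 3 `CCCc1nc(-c2ccccc2)c(CNCCN2CCN(c3ccccc3C)CC2)o1`: 51.3%

In an assay on HEK293 cells for inhibition of Voltage-dependent T-type calcium channel subunit alpha-1G (Homo sapiens), read by fluorescence, tested at 10 uM (a lower number here means less inhibition, a higher number more inhibition at the concentration tested (going by the name of the read-out)), compound 2 stands highest of the three numbers, beyond the scatter from both compound 3 and compound 1. Compound 4 `CCCc1nc(-c2ccccc2)c(CNCCCN2CCN(c3ccc(C)c(C)c3)CC2)o1` differs from compound 2 by 3,4-dimethylphenyl in place of 3-chlorophenyl on an amine nitrogen in a ring. For the measured compounds named here, the only single-point step measured, a number 11.6 percentage points higher from compound 1 to compound 3 (beyond the scatter), concerns a different exchange of groups on the aryl ring and bears on the present change only loosely; no measured pair shows this exchange itself. A small step in either direction, or none beyond the scatter, is therefore expected in this assay for compound 4. Compound 4 is estimated at 60%, with a range from 42% to 78%, which means an expected step of a number 5.9 percentage points lower from compound 2 to compound 4 (within the scatter).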

Compound 4, a percentage reported as inhibition, at one concentration (the size of the read-out at that concentration, not a potency): 54.6%
Compound 4: the middle estimate sits 5.4 percentage points above what was measured, and the stated range covers the measured number.
By their numbers in this assay, from the lowest: compound 1; then compounds 3 and 4 (each within the scatter of the next); then compound 2.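

In this assay, the exchange of 3-chlorophenyl for 3,4-dimethylphenyl on the amine nitrogen in a ring gives a number 11.3 percentage points lower from compound 2 to compound 4 (beyond the scatter). For the compounds shown here, this is the first measured step for this exchange, and it shows that the aryl group still moves the number when the chain of compound 2 is kept. Nothing measured here explains the step. Open, as far as these compounds go, is whether the change comes from losing the chlorine or from adding the two methyl groups. A 3-methylphenyl or 4-chlorophenyl group on the same chain could separate these.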